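Chloro for tert-Butyl on a Distant Ring

The compounds below may be only part of what the source reports. "The series", "measured", "known", "first", "only" and "open" are said of these compounds alone.

Compound 1 `COc1cccc(CNCCCNc2ccnc3cc(Oc4ccccc4)ccc23)c1O` and compound 2 `CC(C)(C)c1ccc(Oc2ccc3c(NCCCNCc4ccco4)ccnc3c2)cc1` were both examined in a physicochemical assay for acid dissociation. In this assay compound 1 gives 9.28, and compound 2 gives 9.28, so compound 2 stands level with compound 1, within the scatter. Compound 3 `Clc1ccc(Oc2ccc3c(NCCCNCc4ccco4)ccnc3c2)cc1` differs from compound 2 only by chloro in place of tert-butyl on an aromatic carbon. The two measured compounds, which differ in far more than this, give the same reading, and no step beyond the scatter is expected here; the expected step is a number 0.03 log units lower from compound 2 to compound 3 (within the scatter). Compound 3 is therefore estimated at 9.25, with a range from 8.95 to 9.55.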

Compound 3, acid dissociation constant: 9.28
Beside the measured number, compound 3's estimate is 0.03 log units below it; the range from low to high includes it.
By their numbers in this assay, from the lowest: compounds 1, 2 and 3 (each within the scatter of the next).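

In this assay, chloro in place of tert-butyl on the aromatic carbon gives no change at the digits printed from compound 2 to compound 3 (within the scatter). Going by these compounds alone, compound 1 and compound 2 differ in more than one place, so this pair is the first to isolate this position, and going from four heavy atoms to one there leaves the reading level. Both groups, however, carry no net charge and no hydrogen-bond donors or acceptors. Going by these compounds, whether an amine or a carboxylic acid at this position would also leave the reading in this assay level remains open. No evidence shown bears on why the reading stays level.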